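The source may hold more compounds than are shown below. What is called first, only, known or untested is meant among the compounds shown, and "the series" means these compounds.

Measured compounds:
compound 1 `COc1cc(NC(=O)Nc2cc(Nc3ccc(OC)c(C)c3)ncn2)cc(OC)c1` gives 48.3%
compound 2 `COc1ccc(OC)c(Nc2cc(NC(=O)Nc3c(Cl)cccc3Cl)ncn2)c1` gives 94.1%
compound 3 `COc1cc(Br)ccc1Nc1cc(NC(=O)Nc2c(Cl)cccc2Cl)ncn1` gives 42.7%

All three were tested in a functional assay on HCC827 cells (Homo sapiens) for inhibition, read by MTT assay, with a stated time of 48 h, tested at 10 uM; a lower number here means less inhibition, a higher number more inhibition at the concentration tested (going by the name of the read-out). Compound 1 stands second highest of the three numbers; its value and that of compound 3 lie within the usual scatter of each other, so no order between them can be read, while compound 2 stands beyond the scatter above compound 1. Compound 4 `CCc1cccc(Nc2cc(NC(=O)Nc3cc(OC)cc(OC)c3)ncn2)c1` has not yet been measured. It differs from compound 1 in one place: 3-ethylphenyl in place of 4-methoxy-3-methylphenyl on a nitrogen on an aromatic ring. Within the data shown here, no pair of measured compounds shows this change, so its size is unknown; the step from compound 1 to compound 4 is expected to stay within the scatter, a number 3.3 percentage points lower from compound 1 to compound 4 (within the scatter). Compound 4 is therefore estimated at 45%, in the range from 22% to 68%.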

Compound 4, a percentage reported as inhibition, at one concentration (the size of the read-out at that concentration, not a potency): 52.6%
For compound 4 the middle estimate is 7.6 percentage points below the measured one, and the stated range covers the measured number.
By their numbers in this assay, from the lowest: compounds 3, 1 and 4 (each within the scatter of the next); then compound 2.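

In this assay, 3-ethylphenyl in place of 4-methoxy-3-methylphenyl on a nitrogen on an aromatic ring gives a number 4.3 percentage points higher from compound 1 to compound 4 (within the scatter), the first size seen for this change. At this position, with the rest of compound 1 kept, the read-out therefore does not separate the two groups, although the hydrogen-bond acceptor counted in the leaving group is absent from the entering one. Nothing measured accounts for this result. The compounds shown leave open whether a morpholine or a carboxylic acid in place of the ethyl group would leave the number within the scatter, and whether this change would have a similar size on a compound other than compound 1.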